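The compounds below may be only part of what the source reports. "The series", "measured", "known", "first", "only" and "open" are said of these compounds alone.

Measured compounds:
compound 1, `CC1=C(C(=O)OCc2ccccc2)C(c2ccoc2)NC(=O)N1` — 41%
compound 2, `CC1=C(C(=O)OCc2ccccc2)C(c2ccsc2)NC(=O)N1` — 57%

Compound 1 `CC1=C(C(=O)OCc2ccccc2)C(c2ccoc2)NC(=O)N1` and compound 2 `CC1=C(C(=O)OCc2ccccc2)C(c2ccsc2)NC(=O)N1` share one core and were both tested in an assay on membranes from CHO cells for displacement of a labelled ligand from adenosine receptor A1 (Homo sapiens), read by scintillation counting, with a stated time of 60 min, tested at 1 uM; on this read-out higher numbers stand for more inhibition at the one concentration tested (going by the name of the read-out) and lower numbers for less inhibition. In this assay compound 1 gives 41%, while compound 2 gives 57%. Compound 1 therefore stands lowest of the two numbers. Within the data shown here, the single measured step, a number 16 percentage points higher from compound 1 to compound 2 (beyond the scatter), came with thiophen-3-yl in place of furan-3-yl on a saturated ring carbon.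

Compound 3 `CC1=C(C(=O)OC2CCC2)C(c2ccoc2)NC(=O)N1` differs from compound 1 at another place: cyclobutyl in place of benzyl on an oxygen next to a carbonyl group. Among the measured compounds shown here, no measured step touches the oxygen next to the carbonyl group, so the one step on record does not bear on this change and its size gives no guide. For the measured compounds named here, with no comparable step available, compound 3 is expected to stay near compound 1, so the expected step of a number 6 percentage points lower from compound 1 to compound 3 (within the scatter) is small with a wide range. Compound 3 is estimated at 35% in this assay, between 10% and 65%.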

Compound 3, a percentage reported as inhibition, at one concentration (the size of the read-out at that concentration, not a potency): 20%
Estimate against measurement, compound 3: 15 percentage points above; low and high end bracket the measured number.
By their numbers in this assay, from the lowest: compound 3; then compound 1; then compound 2.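

In this assay, cyclobutyl in place of benzyl on an oxygen next to a carbonyl group gave a number 21 percentage points lower from compound 1 to compound 3 (beyond the scatter). This shows that the group on this oxygen also bears on the read-out, which the earlier step, confined to the saturated ring carbon, could not show. No data at hand give a reason for the drop.

This single pair cannot separate the loss of the six-membered aromatic ring from the drop in heavy atoms, as both change together between benzyl and cyclobutyl. The compounds shown also leave open how a phenethyl group or a plain ethyl chain on the same oxygen would read, and whether thiophen-3-yl would go with a higher number when cyclobutyl is on that oxygen.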